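From 4-fluorophenyl to cyclopentyl on compound 3

This account rests on a few compounds, and the source may have more. Where it says the series, first, only, none or still open, it means among the compounds named here.

In a functional assay on MCF7 cells (Homo sapiens) for cytotoxicity, read by WST assay, with a stated time of 72 h (a higher number here means a weaker inhibitor, a lower number a stronger inhibitor), compound 1 `O=C1Nc2c(ccc(F)c2F)C1(Cc1ccccc1)c1ccc(O)cc1` reaches only a limit, > 1000 nM. Compound 2 `Cc1c(Cl)ccc2c1NC(=O)C2(c1ccc(O)cc1)C1CCCCCC1` gives 51 nM. Compound 3 `COc1ccc2c(c1C)NC(=O)C2(c1ccc(O)cc1)c1ccc(F)cc1` gives 6.3 nM, the lower of the two actual numbers in this assay. Compound 4 `COc1ccc2c(c1C)NC(=O)C2(c1ccc(O)cc1)C1CCCC1` carries cyclopentyl in place of 4-fluorophenyl on a saturated ring carbon. For the measured compounds named here, no measured pair isolates this change. Compound 2 also carries a non-aromatic ring of carbon only, and it stands at 51 nM against 6.3 nM for compound 3, although other groups differ as well. A weakening beyond the scatter is therefore expected in this assay, with an expected step of a 4.8-fold higher number from compound 3 to compound 4 (0.68 log units; beyond the scatter). For compound 4 the estimated value is 30 nM, within an estimated range of 8 nM to 150 nM.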

Compound 4, half-maximal inhibitory concentration: 1 nM
The estimate for compound 4 lay 30-fold (1.48 log units) above the measured number, and the stated range ends above it.
By their numbers in this assay, from the lowest: compound 4; then compound 3; then compound 2. At a limit, above all of these: compound 1.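

In this assay, replacing 4-fluorophenyl with cyclopentyl on this saturated ring carbon gives a 6.3-fold lower number from compound 3 to compound 4 (0.80 log units; beyond the scatter) and so shows that, on this core, an aromatic ring is not required at this place. The step comes with no change in the counts of hydrogen-bond donors or acceptors, as neither group carries any. Nothing measured here bears on why the number falls. From the compounds shown here alone, whether cyclohexyl, an open chain such as isopropyl, or a cyclopentyl ring carrying an amine would hold this potency on the same core remains open.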